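Hydroxy added to compound 3

The source may hold more compounds than are shown below. What is called first, only, known or untested is meant among the compounds shown, and "the series" means these compounds.

In a functional assay on A2780 cells (Homo sapiens) for inhibition, read by trypan blue exclusion, with a stated time of 72 h (on this read-out lower numbers stand for stronger inhibition of growth and higher numbers for weaker inhibition of growth), compound 3 `Cc1c(-c2ccc(O)cc2)[nH]c2ccccc12` gives > 20000 nM, which is a limit and not a number. Compound 1 `CCCn1c(-c2ccc(O)cc2)c(C)c2ccccc21` gives 9000 nM, and compound 2 `CCCn1c(-c2ccc(O)cc2)c(C)c2cc(O)ccc21` gives 2300 nM. Replacing propyl with hydrogen on the aromatic nitrogen gave an at least 2.2-fold higher number from compound 1 to compound 3 (0.34 log units; beyond the scatter).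

Compound 4 `Cc1c(-c2ccc(O)cc2)[nH]c2ccc(O)cc12` carries hydroxy in place of hydrogen on an aromatic carbon, hydroxy in place of hydrogen on an aromatic carbon. For the measured compounds named here, the same change in the propyl pair gave a 3.9-fold lower number from compound 1 to compound 2 (0.59 log units; beyond the scatter), the only direct precedent. A step of similar size toward a lower number is therefore expected, although the starting point is only a limit and a further limit remains possible. The expected change is an at least 1.6-fold lower number from compound 3 to compound 4 (0.22 log units; that floor lies within the scatter). Compound 4 is estimated at 12000 nM, with an expected range of 5000 nM to 25000 nM.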

Compound 4, concentration for 50% growth inhibition: 11000 nM
For compound 4 the middle estimate is 1.1-fold (0.04 log units) above the measured one, within the range that was stated.
By their numbers in this assay, from the lowest: compound 2; then compounds 1 and 4 (each within the scatter of the next). At a limit, above all of these: compound 3.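

With hydrogen on the aromatic nitrogen, hydroxy in place of hydrogen on this aromatic carbon gives an at least 1.8-fold lower number from compound 3 to compound 4 (0.25 log units; that floor lies within the scatter), which agrees in direction with the propyl pair, although it is measured against a limit and its floor is small. Compound 4 also gives the first propyl step read between two numbers rather than against a limit, a 4.8-fold higher number from compound 2 to compound 4 (0.68 log units; beyond the scatter). The propyl change therefore now stands on two cores: the same change on two cores in this assay, an at least 2.2-fold higher number (0.34 log units; beyond the scatter) from compound 1 to compound 3 and a 4.8-fold higher number (0.68 log units; beyond the scatter) from compound 2 to compound 4; the limit leaves it open whether they differ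

The nitrogen carries only hydrogen or propyl here, leaving open how a longer chain or an aminoalkyl chain would read. From the compounds shown here alone, at this carbon, methoxy or fluorine in place of hydroxy also remains open.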